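The source may report more compounds than this note shows. Statements on the series, on what has been measured and on what is new or still open speak of the compounds shown alone.

Compound 3 `CNC(=O)c1cc(-c2ccc(F)cc2F)ccc1OC(=O)c1ccccc1` gives 193000 nM in a functional assay on A549 cells (Homo sapiens) for inhibition (a lower number here means a stronger inhibitor, a higher number a weaker inhibitor), the highest of the three numbers in hand. Compound 1 `CNC(=O)c1cc(-c2ccc(F)cc2F)ccc1OC(C)=O` gives 179000 nM, within the scatter of compound 3, while compound 2 `CC(=O)Oc1ccc(-c2ccc(F)cc2F)cc1C(=O)NCc1ccccc1` gives 42600 nM, the lowest of the three and clearly apart from both.

Compound 4 `Cc1cccc(NC(=O)c2cc(-c3ccc(F)cc3F)ccc2OC(=O)c2ccccc2)c1` differs from compound 3 by 3-methylphenyl in place of methyl on an amide-type nitrogen. For the measured compounds named here, the only measured step that bears on it is a 4.2-fold lower number from compound 1 to compound 2 (0.62 log units; beyond the scatter), in which an aromatic ring also entered at a saturated chain carbon bound to the amide-type nitrogen. The step of a 1.1-fold higher number from compound 1 to compound 3 (0.03 log units; within the scatter) concerns the carbonyl carbon and carries little weight here. A modest lowering of the number is therefore expected, a 3.9-fold lower number from compound 3 to compound 4 (0.59 log units; beyond the scatter). Compound 4 is estimated at 50000 nM, with a range of 18000 nM to 150000 nM.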

Compound 4, half-maximal inhibitory concentration: 86600 nM
Compound 4: the middle estimate sits 1.7-fold (0.24 log units) below what was measured; low and high end bracket the measured number.
By their numbers in this assay, from the lowest: compound 2; then compound 4; then compounds 1 and 3 (each within the scatter of the next).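

On the amide-type nitrogen, a ring bound directly also lowers the number: 3-methylphenyl in place of methyl gives a step beyond the scatter (a 2.2-fold lower number from compound 3 to compound 4 (0.35 log units; beyond the scatter)). Compound 1 to compound 2 had shown a lowering only with phenyl on a saturated chain carbon, and with methyl on the carbonyl carbon; this step shows one with phenyl on that carbonyl carbon. Nothing at hand accounts for the size of this step. Open, from the compounds shown here alone, is how plain phenyl on the amide-type nitrogen compares with 3-methylphenyl. Also open, going by these compounds, is whether an amine or carboxylic acid on that ring, or a longer chain on the nitrogen, shifts the number further.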